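The source may report more compounds than this note shows. Statements on the series, on what has been measured and on what is new or still open speak of the compounds shown alone.

In a functional assay (aorta) with Rattus norvegicus as the target (on this read-out higher numbers stand for an effect only at larger amounts of compound and lower numbers for an effect already at smaller amounts), compound 3 `COc1ccc(-c2nc(C(=O)N3CCOCC3)sc2-c2ccc(OC)cc2)cc1` reads only as a limit, < 100 uM, and this is the limit of < 100 uM in this assay, at which 1 of the 3 values shown sits. Compound 4 `COc1ccc(-c2nc(CCC(=O)O)sc2-c2ccc(OC)cc2)cc1` carries 2-carboxyethyl in place of (morpholin-4-yl)carbonyl on an aromatic carbon of the shared core: 2-carboxyethyl in place of (morpholin-4-yl)carbonyl on an aromatic carbon. Going by the values given here, the only measured step bearing on this change is a step that the limit leaves unreadable from compound 2 to compound 3, so no size carries over from it. Because compound 1 `COc1ccc(-c2nc(CNC(=O)C3=NNC(=O)CC3)sc2-c2ccc(OC)cc2)cc1` gives 7.3 uM and compound 2 `COc1ccc(-c2nc(C(=O)N(C)C)sc2-c2ccc(OC)cc2)cc1` gives 3 uM, a number of similar order is expected for compound 4, with wide margins. The expected step is a step that the limit leaves unreadable from compound 3 to compound 4, its size and direction resting on an estimate set against a limit. Compound 4 is estimated at 10 uM, with an expected range of 2 uM to 50 uM.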

Compound 4, concentration for half-maximal effect: > 100 uM
Compound 4: only a limit was reported; the forecaster's own chance of this, stated with the estimate: 20%; middle value at least 10-fold (1.00 log units) away from the limit.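

In this assay compound 4 stands only as a limit: the limit of > 100 uM in this assay, at which 1 of the 4 values shown sits.

Replacing dimethylcarbamoyl with 2-carboxyethyl on this aromatic carbon gives an at least 33-fold higher number from compound 2 to compound 4 (1.52 log units; beyond the scatter), so this position does not tolerate every replacement. The comparison with the larger ring-bearing side chain gives an at least 13-fold higher number from compound 1 to compound 4 (1.13 log units; beyond the scatter). Replacing (morpholin-4-yl)carbonyl with 2-carboxyethyl on this aromatic carbon gives a number no lower from compound 3 to compound 4 (the limit leaves the size open).

Open, from the compounds shown here alone, is whether the carboxylic acid or the saturated chain carrying it sets this result. A methyl ester on the same chain, or a carboxylic acid set directly on the aromatic carbon, would separate the two.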